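This account rests on a few compounds, and the source may have more. Where it says the series, first, only, none or still open, it means among the compounds named here.

Of the compounds shown here, three from this series have been tested in an assay on microsomes from liver for inhibition of sterol O-acyltransferase 1 (Rattus norvegicus); a lower number here means a stronger inhibitor, a higher number a weaker inhibitor. Compound 1 `C[C@]1(O)CC(=O)OC(CSc2nc(-c3ccccc3)c(-c3ccccc3)[nH]2)C1` gives 140 nM in this assay, the lowest number of the three. Compound 2 `COc1ccc(-c2nc(SCC3C[C@@](C)(O)CC(=O)O3)[nH]c2-c2ccc(OC)cc2)cc1`, which carries methoxy groups on both aromatic rings, gives 340 nM in this assay, and that gap to compound 1 is beyond the scatter. Compound 3 `Cn1c(SC[C@H]2C[C@@](C)(O)CC(=O)O2)nc(-c2ccccc2)c1-c1ccccc1.Cn1c(SC[C@H]2C[C@](C)(O)CC(=O)O2)nc(-c2ccccc2)c1-c1ccccc1`, measured as a mixture of two stereoisomers and bearing a methyl group on the ring nitrogen of the core, gives 2600 nM in this assay, also beyond the scatter from compound 1. On these numbers compound 1 is the strongest inhibitor of the three.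

The next compound, compound 4 `c1ccc(-c2nc(SCC3CCCCO3)[nH]c2-c2ccccc2)cc1`, has not yet been measured. It differs from compound 1 in one place: a group of 6 heavy atoms (5 carbon, 1 oxygen; one six-membered non-aromatic ring with 1 hetero atom) in place of a group of 9 heavy atoms (6 carbon, 3 oxygen; one six-membered non-aromatic ring with 1 hetero atom), on a saturated chain carbon bound to a sulfur. The hydroxyl and the lactone of compound 1 are thereby gone, and only the oxane ring remains on the chain bound to the sulfur. For the measured compounds named here, no measured pair in this set covers such a change, so there is no step to lean on. Compound 4 is nonetheless expected to give a higher number in this assay than compound 1, with an estimate of 1200 nM, within a range from 350 nM to 4500 nM. The step this implies, an 8.6-fold higher number from compound 1 to compound 4 (0.93 log units; beyond the scatter), is expected to lie beyond the scatter.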

Compound 4, half-maximal inhibitory concentration: 210 nM
Compound 4: the middle estimate sits 5.7-fold (0.76 log units) above what was measured; measured number below the stated range.
By their numbers in this assay, from the lowest: compounds 1, 4 and 2 (each within the scatter of the next, the first and the last beyond it); then compound 3.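

In this assay, putting oxan-2-yl in place of the larger ring group, on a saturated chain carbon bound to a sulfur, amounts to a 1.5-fold higher number from compound 1 to compound 4 (0.18 log units; within the scatter). For the compounds shown here, this is the first look at this position, and it shows that neither the hydroxyl nor the lactone of compound 1 is required for a number of this size in this assay, as compound 4 keeps only the oxane ring there and stays within the scatter of compound 1. Nothing available here explains why removing these groups leaves the number within the scatter.

Every compound shown still has a six-membered non-aromatic ring with one hetero atom on this chain, so it remains open whether the ring itself matters or whether a plain butyl chain, a carboxylic acid or an amine in its place would give a similar number. As far as these compounds go, it is equally open whether oxan-2-yl would behave the same way alongside the methoxy groups of compound 2 or the methyl group on the ring nitrogen of compound 3.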